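Lipophilicity notes: trimming the ether chain in a diaryl acid series

The source may report more compounds than this note shows. Statements on the series, on what has been measured and on what is new or still open speak of the compounds shown alone.

Compound 1 `Cc1cc(OCC(C)C)cc(C)c1-c1cccc(COc2ccc(OCC(=O)O)c(F)c2)c1` carries an isobutoxy group on one ring of the shared core; in a physicochemical assay for lipophilicity, using the shake flask method, in phosphate buffer, measured as octanol-water partition, with a stated time of 24 h, at pH 7.4, tested at 100 uM (on this read-out higher numbers stand for higher lipophilicity and lower numbers for lower lipophilicity), compound 1 is recorded as "not determined" (no result reported), so it stands without a number. Compound 3 `Cc1cc(OCC(=O)N2CCOCC2)cc(C)c1-c1cccc(COc2ccc(OCC(=O)O)c(F)c2)c1` likewise is recorded as "not determined" (no result reported) in this assay. Going by the values given here, the only number comes from compound 2 `Cc1cc(O)cc(C)c1-c1cccc(COc2ccc(OCC(=O)O)c(F)c2)c1`, the free phenol, which in this assay gives 2.37.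

Compound 4 `COc1cc(C)c(-c2cccc(COc3ccc(OCC(=O)O)c(F)c3)c2)c(C)c1` is the next compound to be measured. Against compound 1 the change is hydrogen in place of isopropyl on a saturated chain carbon bound to an oxygen on an aromatic ring; read one bond further out, isobutoxy becomes methoxy. With no value for compound 1, the step from compound 1 to compound 4 cannot be computed; the expectation is that compound 4 will read lower than compound 1 would, by more than the usual scatter, with the three carbons that leave.

For compound 4 itself the estimate is anchored on compound 2, because compound 2 gives 2.37 and compound 4 differs from it only by methyl in place of hydrogen on the phenol oxygen. The distribution coefficient of compound 4 is therefore expected at 3, with a range from 2.4 to 3.6.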

Compound 4, distribution coefficient: 3.2
Beside the measured number, compound 4's estimate is 0.20 log units below it, and the stated range covers the measured number.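

Methyl in place of hydrogen on an oxygen on an aromatic ring gives a number 0.83 log units higher from compound 2 to compound 4 (beyond the scatter) in this assay, the only measured change at this position among the compounds shown. Going by these compounds alone, this gives the series one measured comparison between a free phenol and an ether, with methoxy as the only ether carrying a number, while the steps that would link compound 1 or compound 3 to the other compounds cannot be read. No available evidence explains the size of this step.

As far as these compounds go, with a single ether value, no trend with chain length can be drawn, and it remains open where an ethoxy or n-propoxy group would fall relative to compound 4. From the compounds shown here alone, it is also open how an amine or a carboxylic acid at the end of such a chain would alter the read-out.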